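The source may hold more compounds than are shown below. What is called first, only, known or untested is meant among the compounds shown, and "the series" means these compounds.

Measured compounds in a functional assay on PC-12 cells (Rattus norvegicus) for cytotoxicity, read by MTT assay, with stated times of 2 h and 24 h, tested at 1 uM; on this read-out lower numbers stand for a weaker effect and higher numbers for a stronger effect at the one concentration tested:
- compound 1, `CC(C)(C)c1ccc(-n2nc(-c3ccc(C(F)(F)F)cc3O)nc2-c2ccccc2O)cc1`, gives 67.3%
- compound 2, `Oc1cc(C(F)(F)F)ccc1-c1nc(-c2ccccc2O)n(-c2cccc(F)c2)n1`, gives 67.2%

Compound 1 holds the higher of the two numbers, but the step of a number 0.1 percentage points lower from compound 1 to compound 2 (within the scatter) is within the scatter, so the two compounds cannot be told apart on this read-out. Within the data shown here, the one measured change, a 3-fluorophenyl in place of 4-(tert-butyl)phenyl on an aromatic nitrogen, left the read-out where it was.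

Compound 3, `Cc1ccc(-n2nc(-c3ccc(C(F)(F)F)cc3O)nc2-c2ccccc2O)c(C)c1`, is not yet measured. It differs from compound 1 by 2,4-dimethylphenyl in place of 4-(tert-butyl)phenyl on an aromatic nitrogen. Among the measured compounds shown here, this is the same position that was varied between compound 1 and compound 2, and the only step that bears on it is a number 0.1 percentage points lower from compound 1 to compound 2 (within the scatter), which was flat. For the measured compounds named here, the series so far gives no sign that the group on this aromatic nitrogen moves the read-out in this assay at the tested concentration, though only one such exchange has been measured.

On that basis no step beyond the scatter is expected for compound 3, and the step of a number 1.3 percentage points lower from compound 1 to compound 3 (within the scatter) is estimated to stay within it. Compound 3 is therefore expected to give about 66% in this assay, in a range of 56% to 76%.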

Compound 3, a percentage reported as activity, at one concentration (the size of the read-out at that concentration, not a potency): 73.7%
Compound 3: the middle estimate sits 7.7 percentage points below what was measured; the measured number falls inside the stated range.
By their numbers in this assay, from the lowest: compounds 2, 1 and 3 (each within the scatter of the next).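

With 2,4-dimethylphenyl in place of 4-(tert-butyl)phenyl on the aromatic nitrogen, this assay shows a number 6.4 percentage points higher from compound 1 to compound 3 (within the scatter), and with the same group in place of 3-fluorophenyl it shows a number 6.5 percentage points higher from compound 2 to compound 3 (within the scatter). The flat reading at this position therefore no longer rests on a single exchange: three differently substituted phenyl groups, carrying a fluorine, a tert-butyl group or two methyl groups, now stand within the scatter of one another at the one concentration tested, so this set gives no ranking among them. Nothing available accounts for this similarity.

From the compounds shown here alone, all three compounds carry a carbon-only six-membered aromatic ring on this nitrogen, so it remains open whether a longer alkyl chain, or a phenyl group bearing an amine or a carboxylic acid, would stay level with them in this assay. The 2-hydroxyphenyl and 2-hydroxy-4-(trifluoromethyl)phenyl groups are the same throughout, so these compounds say nothing about how changes to either would affect the read-out.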